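Adding a Methoxy Group: From Compound 3 to Compound 4

The compounds below may be only part of what the source reports. "The series", "measured", "known", "first", "only" and "open" are said of these compounds alone.

Measured compounds:
Compound 1, `COc1ccc(NCc2ccc(/C=C/C(=O)Nc3ccccc3N)cc2)cc1OC`: 5000 nM
Compound 2, `COc1cc(NCc2ccc(/C=C/C(=O)Nc3ccccc3N)cc2)cc(OC)c1OC`: 2000 nM
Compound 3, `COc1ccc(CNc2ccc(C(=O)Nc3ccccc3N)cc2)cc1OC`: 600 nM

In a functional assay on HCT-116 cells (Homo sapiens) for antiproliferative activity, read by MTT assay (a higher number here means a weaker inhibitor, a lower number a stronger inhibitor), compound 1 gives 5000 nM and compound 2 gives 2000 nM. The two differ by methoxy in place of hydrogen on an aromatic carbon, and that change brought a 2.5-fold lower number from compound 1 to compound 2 (0.40 log units; beyond the scatter). Compound 3 gives 600 nM in this assay, the lowest number of the three measured compounds; how the core of compound 3 differs from the core of compound 1 is not broken down here.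

Compound 4, `COc1cc(CNc2ccc(C(=O)Nc3ccccc3N)cc2)cc(OC)c1OC`, has not yet been measured in this assay. It differs from compound 3 by methoxy in place of hydrogen on an aromatic carbon, the same change that separates compound 1 from compound 2, as the surroundings of the place are described in the same words in both pairs. The account therefore rests on one prior step only. If the change behaves as it did from compound 1 to compound 2, compound 4 is expected to show a 2.5-fold lower number from compound 3 to compound 4 (0.40 log units; beyond the scatter) relative to compound 3, because the earlier step was a 2.5-fold lower number from compound 1 to compound 2 (0.40 log units; beyond the scatter). On that basis compound 4 is estimated at 240 nM in this assay, within a range of 100 nM to 700 nM.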

Compound 4, half-maximal inhibitory concentration: 2000 nM
For compound 4 the middle estimate is 8.3-fold (0.92 log units) below the measured one; measured number above the stated range.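

In this assay, methoxy in place of hydrogen on an aromatic carbon gave a 3.3-fold higher number from compound 3 to compound 4 (0.52 log units; beyond the scatter), so the step did not keep its direction when it moved from the core of compound 1 to the core of compound 3. Set side by side, the two steps clearly differ: the same change on two cores in this assay, a 2.5-fold lower number (0.40 log units; beyond the scatter) from compound 1 to compound 2 and a 3.3-fold higher number (0.52 log units; beyond the scatter) from compound 3 to compound 4, 8.3-fold (0.92 log units) apart, beyond the scatter of two such steps. For the compounds shown here, this shows that, in this series, the result of the change on one core could not be carried over to the other, but with only one pair on each core it does not show which difference between the cores is responsible, or how the change would behave on any further core.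

The compounds shown leave open whether the same reversal would appear with another group at that place, such as a hydroxyl, a chlorine atom or an amine. They also leave open how the change would read on a core that carries only some of the differences between the core of compound 1 and the core of compound 3.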